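The source may report more compounds than this note shows. Statements on the series, on what has been measured and on what is new or still open speak of the compounds shown alone.

The compounds in this series share a core and were tested in an ADME assay on cells (Fibroblast, Gallus gallus) for cytotoxicity, read by CCK-8 assay, with a stated time of 48 h; on this read-out lower numbers stand for higher toxicity in this test and higher numbers for lower toxicity in this test. Compound 1 `CCC(CC)Oc1cccc(CN[C@H]2CC(C(=O)O)=C[C@@H](OC(CC)CC)[C@@H]2NC(C)=O)c1` gives > 200000 nM, which is a limit of the assay and not a number. Compound 2 `CCC(CC)O[C@@H]1C=C(C(=O)O)C[C@H](NCc2cccc(SC(C)CC)c2)[C@H]1NC(C)=O` gives > 200000 nM, which is also a limit, so its standing is known only from one side. The record so far is the limit of > 200000 nM in this assay, at which 2 of the 2 values shown sit.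

Compound 3 `CCC(CC)O[C@@H]1C=C(C(=O)O)C[C@H](NCc2cccc(-c3ccc(SC)cc3)c2)[C@H]1NC(C)=O` differs from compound 2 in one place: 4-(methylsulfanyl)phenyl in place of (sec-butyl)sulfanyl on an aromatic carbon. Here 4-(methylsulfanyl)phenyl replaces (sec-butyl)sulfanyl on an aromatic carbon, meta to a large group. Within the data shown here, the only measured step, a step that the two limits leave unreadable from compound 1 to compound 2, has no readable size and concerns a different exchange, so it gives no measure for this change. Neither compound 1 nor compound 2 carries the entering group, which leaves the estimate loosely held. Since compound 2 gives the limit > 200000 nM in this assay, compound 3 is expected to stay close to it. The expected change is an at least 1.1-fold lower number from compound 2 to compound 3 (0.07 log units; that floor lies within the scatter), with no step beyond the scatter foreseen. For compound 3 the estimated value is 170000 nM, with an expected range from 80000 nM to 300000 nM.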

Compound 3, half-maximal cytotoxic concentration: > 200000 nM
Compound 3: no number, only a limit; the forecaster's own chance of this, stated with the estimate: 70%; middle value at least 1.1-fold (0.07 log units) from the limit.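

In this assay compound 3 gives > 200000 nM as a limit of the assay and not a number. Among these compounds, no step between compound 3 and compound 1 or compound 2 can be read, as their values are limits too. The compounds shown leave open whether any of these exchanges changes the read-out, since the record holds only this: the limit of > 200000 nM in this assay, at which 3 of the 3 values shown sit.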